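Two Limits and a Third Variant at the Amide Nitrogen

This account rests on a few compounds, and the source may have more. Where it says the series, first, only, none or still open, it means among the compounds named here.

In an assay on isolated protein for inhibition of receptor-type tyrosine-protein phosphatase C (Homo sapiens), read by spectrophotometry (a lower number here means a stronger inhibitor, a higher number a weaker inhibitor), the two measured compounds stand as follows:
Compound 1 `O=C(COc1ccc2cc(C(O)(C(F)(F)F)C(F)(F)F)c(O)cc2c1)Nc1ccccc1`: > 20000 nM, a limit of the assay.
Compound 2 `O=C(COc1ccc2cc(C(O)(C(F)(F)F)C(F)(F)F)c(O)cc2c1)NCc1ccc(F)cc1`: > 20000 nM, again a limit of the assay.

Compound 2 therefore stands only at a limit, not at a number. For the measured compounds named here, the single step, a step that the two limits leave unreadable from compound 1 to compound 2, is left unreadable, since (the limit of > 20000 nM in this assay, at which 2 of the 2 values shown sit).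

Compound 3 `CC(C)c1ccc(NC(=O)COc2ccc3cc(C(O)(C(F)(F)F)C(F)(F)F)c(O)cc3c2)cc1` changes compound 2 in one place: 4-isopropylphenyl in place of 4-fluorobenzyl on an amide-type nitrogen. No measured step gives a readable size for this kind of exchange, so nothing shown points in either direction. With both measured compounds sitting at the limit, compound 3 is expected to sit near it as well, so the step that the limit leaves unreadable from compound 2 to compound 3 is estimated to be small and uncertain. Compound 3 is expected to give about 30000 nM, estimated between 5000 nM and 150000 nM.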

Compound 3, half-maximal inhibitory concentration: 7800 nM
Compound 3: middle estimate off by 3.8-fold (0.59 log units), on the high side, and the stated range covers the measured number.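

Compound 3 is the only one of the three shown to give a number rather than a limit in this assay, so a group on this amide nitrogen can bring measurable inhibition. Exchanging 4-fluorobenzyl for 4-isopropylphenyl gives an at least 2.5-fold lower number from compound 2 to compound 3 (0.40 log units; beyond the scatter), and isopropyl in place of hydrogen on an aromatic carbon of the phenyl group gives an at least 2.5-fold lower number from compound 1 to compound 3 (0.40 log units; beyond the scatter), so on this phenyl amide the isopropyl alone separates a measurable compound from one at the limit. Both steps are minimum sizes only, because their starting compounds give no number: the limit of > 20000 nM in this assay, at which 2 of the 3 values shown sit.

Going by these compounds, the true size of either step remains open. So does whether a carboxylic acid, an amine or a longer alkyl chain in place of the isopropyl would give a lower or a higher number.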